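The source may hold more compounds than are shown below. What is called first, only, known or untested is meant among the compounds shown, and "the series" means these compounds.

Measured so far:
- compound 1 `CCc1noc(C)c1[C@@H]1C[C@@](C)(c2ccc(F)cc2F)N=C(N)S1`: 41%
- compound 2 `Cc1noc(-c2ccccc2)c1[C@@H]1C[C@@](C)(c2ccc(F)cc2F)N=C(N)S1`: 6%
- compound 3 `Cc1noc(C(F)F)c1[C@@H]1C[C@@](C)(c2ccc(F)cc2F)N=C(N)S1`: 59%

These values come from an ADME assay on microsomes from liver (Mus musculus) for metabolic stability, with a stated time of 10 min, tested at 0.5 uM; on this read-out higher numbers stand for a more stable compound and lower numbers for a less stable compound. Compound 3, at 59%, stands highest of the three, ahead of compound 1 at 41% and compound 2 at 6%, and both gaps lie beyond the scatter.

The next compound is compound 4 `Cc1nocc1[C@@H]1C[C@@](C)(c2ccc(F)cc2F)N=C(N)S1`, which has hydrogen in place of difluoromethyl on an aromatic carbon, next to the ring oxygen: hydrogen in place of difluoromethyl on an aromatic carbon.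

Among the measured compounds shown here, only one measured step bears on this carbon: a number 53 percentage points higher from compound 2 to compound 3 (beyond the scatter), a large step beyond the scatter, with difluoromethyl in place of phenyl. For the measured compounds named here, that step shows how much this place can matter in this assay, but no measured compound carries hydrogen there, so it gives neither a size nor a direction for the new change. The working expectation is therefore no step beyond the scatter, held with wide uncertainty. The expected change is a number 4 percentage points lower from compound 3 to compound 4 (within the scatter). For compound 4 the estimated value is 55%, with an expected range of 30% to 80%.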

Compound 4, percent of the compound remaining: 80%
Beside the measured number, compound 4's estimate is 25 percentage points below it, within the range that was stated.
By their numbers in this assay, from the lowest: compound 2; then compound 1; then compound 3; then compound 4.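

In this assay, hydrogen on this aromatic carbon gives a number 21 percentage points higher from compound 3 to compound 4 (beyond the scatter) and, set against phenyl at the same place, a number 74 percentage points higher from compound 2 to compound 4 (beyond the scatter). Among the compounds shown here, the earlier compounds showed only that one group here could outscore another, whereas compound 4 now shows that neither difluoromethyl nor phenyl matches hydrogen at this carbon, so the better of those two groups still falls short of having no group there at all. The wider exchange of 3-methyl-1,2-oxazol-4-yl for 3-ethyl-5-methyl-1,2-oxazol-4-yl gives a number 39 percentage points higher from compound 1 to compound 4 (beyond the scatter), which points the same way but alters more than this one carbon.

On these data alone, whether a single fluorine, a methoxy group or an amine on this carbon would stay close to compound 4 at 80% remains open. Nothing shown here gives a reason for these rises.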